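This account rests on a few compounds, and the source may have more. Where it says the series, first, only, none or still open, it means among the compounds named here.

Three compounds have been measured in an ADME assay on U2OS cells (Homo sapiens) for cytotoxicity, with a stated time of 96 h; a higher number here means that more compound is tolerated, a lower number that less compound is tolerated:

compound 1, `CC(C)COc1ccc(CN(Cc2ccncc2)S(=O)(=O)c2ccc(F)c(F)c2)cc1`, which gives 11500 nM;
compound 2, `c1cncc(-c2nc(-c3cccs3)no2)c1`, which gives 66300 nM;
compound 3, `c1cncc(-c2nc(-c3cnccn3)n[nH]2)c1`, which gives 1500 nM.

Among these three numbers compound 1 stands second highest. Compound 2 gives the higher number, and that gap lies beyond the usual scatter of repeated measurements, so compound 2 is tolerated at higher concentrations. Compound 3 gives the lower number, again with a gap beyond the scatter, so compound 3 is tolerated least well of the three. Compounds 2 and 3 share no close structural relationship with compound 1, so they only frame the range without explaining it.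

The next compound, compound 4, is `CC(C)COc1ccc(CN(Cc2ccncc2)S(=O)(=O)c2cccc(F)c2)cc1`. It is built from compound 1 by a single small change:

hydrogen in place of fluoro on an aromatic carbon

Only one fluorine atom is removed, and nothing else in the molecule shifts. Among the compounds with values here, no pair of measured compounds differing in just one place is available to show how large such a change usually is in this assay. With so little altered, the expected step from compound 1 to compound 4 is small, most likely none beyond the scatter in either direction, estimated as a 1.0-fold higher number from compound 1 to compound 4 (0.02 log units; within the scatter). The estimated value for compound 4 is therefore 12000 nM, within a range from 5000 nM to 30000 nM.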

Compound 4, half-maximal cytotoxic concentration: > 200000 nM
Compound 4 ended at the assay's limit; the forecaster's own chance of this, stated with the estimate: 10%; at least 16-fold (1.22 log units) between middle value and limit.
By their numbers in this assay, from the lowest: compound 3; then compound 1; then compound 2. At a limit, above all of these: compound 4.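

Within the data shown here, the first pair in this set that differs in only one place shows that this small change has a large effect in this assay: going from 3,4-difluorophenyl to 3-fluorophenyl gives an at least 17-fold higher number from compound 1 to compound 4 (1.24 log units; beyond the scatter). This step has only a lower bound, since the result for compound 4 is a limit of the assay and not a number: the limit of > 200000 nM in this assay, at which 1 of the 4 values shown sits.

So a ring position that is ortho to a fluoro group and para to a large group is not a neutral spot in this pair, as the loss of a single fluorine atom there moves the tolerated concentration well beyond the scatter, whereas the earlier compounds, which differ from one another in many places, could only frame the range.

Going by these compounds, how far compound 4 really lies past the limit stays open. This single pair does not show what lies behind the jump. Also open, on these data alone, is whether a chloro or methoxy group at this position would behave like fluoro or like hydrogen, and whether removing the other fluoro group, to leave 4-fluorophenyl, would produce a similar step.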